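A Carbamoylmethyl Group Replaces Cyclopropyl on the Ring Nitrogen

This account rests on a few compounds, and the source may have more. Where it says the series, first, only, none or still open, it means among the compounds named here.

In a functional assay on HCT-116 cells (Homo sapiens) for antiproliferative activity, read by MTT assay, with a stated time of 48 h (a lower number here means a stronger inhibitor, a higher number a weaker inhibitor), compound 1 `COc1ccc(-c2cc3c(cn2)[nH]c(=O)n3-c2cc(OC)c(OC)c(OC)c2)cc1O` gives 340 nM. Compound 2 `COc1ccc(-c2cc3c(cn2)n(C2CC2)c(=O)n3-c2cc(OC)c(OC)c(OC)c2)cc1O` returns no number, only a limit of the assay, > 20000 nM; this is the limit of > 20000 nM in this assay, at which 1 of the 2 values shown sits. Compound 3 `COc1ccc(-c2cc3c(cn2)n(CC(N)=O)c(=O)n3-c2cc(OC)c(OC)c(OC)c2)cc1O` differs from compound 2 by carbamoylmethyl in place of cyclopropyl on an aromatic nitrogen. Going by the values given here, the one measured step on that nitrogen is large: an at least 58-fold higher number from compound 1 to compound 2 (1.76 log units; beyond the scatter). Given that step, and with no other substituent measured there, only a modest move toward a lower number is expected for compound 3. The estimated step is an at least 2.0-fold lower number from compound 2 to compound 3 (0.30 log units; that floor lies within the scatter). For compound 3 the expected value is 10000 nM, with an estimated range of 1500 nM to 40000 nM.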

Compound 3, half-maximal inhibitory concentration: 8890 nM
Compound 3: the middle estimate sits 1.1-fold (0.05 log units) above what was measured, and the stated range covers the measured number.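

In this assay, the identity of the substituent on this nitrogen matters, not only its presence: carbamoylmethyl in place of cyclopropyl gives an at least 2.2-fold lower number from compound 2 to compound 3 (0.35 log units; beyond the scatter). Even so, the nitrogen bearing hydrogen keeps the lowest number of the three, with a 26-fold higher number from compound 1 to compound 3 (1.42 log units; beyond the scatter). Compound 2 has only a limit of the assay, so the step from it is a floor and its full size cannot be read: the limit of > 20000 nM in this assay, at which 1 of the 3 values shown sits.

Going by these compounds, whether methyl, an amine, a carboxylic acid or a longer chain on this nitrogen would come closer to compound 1 remains open.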